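The source may report more compounds than this note shows. Statements on the series, on what has been measured and on what is new or still open speak of the compounds shown alone.

Compound 1 `COc1cc(/C=C2\Cc3ccccc3/C(=C\c3ccc([N+](=O)[O-])cc3)C2=O)ccc1O`: 21000 nM
Compound 2 `COc1cc(/C=C2\Cc3ccccc3/C(=C\c3ccc([N+](=O)[O-])cc3)C2=O)cc(OC)c1OC`: > 400000 nM, a limit of the assay rather than a number

Of the compounds shown here, two share the same core and have been tested in a functional assay on HPLF cells (Homo sapiens) for cytotoxicity; a lower number here means that less compound is tolerated, a higher number that more compound is tolerated. Among the measured compounds shown here, compound 1 gives 21000 nM, the only measured number in this set. Compound 2 sits at the limit of > 400000 nM in this assay, at which 1 of the 2 values shown sits, so for it only a limit is known, not a value. For the measured compounds named here, because one of the two results is a limit, no step between measured compounds can be sized here.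

Compound 3 `COc1ccc(/C=C2\Cc3ccccc3/C(=C\c3ccc([N+](=O)[O-])cc3)C2=O)cc1` has not yet been measured in this assay. It differs from compound 1 by 4-methoxyphenyl in place of 4-hydroxy-3-methoxyphenyl on a double-bonded chain carbon bound to a double-bonded ring carbon. Going by the values given here, no measured pair shows this change, so its effect is open; a move of modest size, possibly within the usual scatter, is the most that can be expected. Compound 3 is estimated to give 30000 nM, with a likely range from 8000 nM to 150000 nM. The expected step of a 1.4-fold higher number from compound 1 to compound 3 (0.15 log units; within the scatter) is therefore small, with a slight lean toward more compound being tolerated.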

Compound 3, half-maximal cytotoxic concentration: > 400000 nM
Compound 3: a limit, no number; the forecaster's own chance of this, stated with the estimate: 15%; at least 13-fold (1.12 log units) between middle value and limit.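

Replacing 4-hydroxy-3-methoxyphenyl with 4-methoxyphenyl on a double-bonded chain carbon bound to a double-bonded ring carbon gives, in this assay, an at least 19-fold higher number from compound 1 to compound 3 (1.27 log units; beyond the scatter). This position is therefore sensitive: a single change of group here takes the compound from a measured value to a limit of the assay, and the group that leaves has a hydrogen-bond donor while the group that enters has none. Compound 3 joins compound 2 at that limit, leaving compound 1 as the only compound with a measured number: the limit of > 400000 nM in this assay, at which 2 of the 3 values shown sit.

The compounds shown do not reveal how far compound 3 lies beyond the limit, or whether the donor itself accounts for the step. An amine or a carboxylic acid on the same phenyl ring would test whether other groups can restore a measurable value.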